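This account rests on a few compounds, and the source may have more. Where it says the series, first, only, none or still open, it means among the compounds named here.

Compound 1 `CCCCCn1ccnc1-c1cc(OC)c(OC)c(OC)c1`: 64400 nM
Compound 2 `COc1cc(-c2nccn2-c2ccc3sccc3c2)cc(OC)c1OC`: 17000 nM
Compound 3 `COc1cc(-c2nccn2-c2ccc3[nH]ccc3c2)cc(OC)c1OC`: 2100 nM

In a functional assay on T47D cells (Homo sapiens) for antiproliferative activity, read by MTT assay, with a stated time of 72 h (on this read-out higher numbers stand for weaker inhibition and lower numbers for stronger inhibition), compound 1 gives 64400 nM, the highest of the three numbers and thus the weakest inhibition, beyond the scatter from both others. Compound 4 `COc1ccc(-n2ccnc2-c2cc(OC)c(OC)c(OC)c2)cc1` has not yet been measured. It carries 4-methoxyphenyl in place of pentyl on an aromatic nitrogen. Within the data shown here, no measured pair isolates this change, so the expectation rests on compound 2 at 17000 nM and compound 3 at 2100 nM, which also have a ring-bearing group instead of pentyl on that nitrogen. A clear fall in the number is therefore expected, with an estimated step of an 11-fold lower number from compound 1 to compound 4 (1.03 log units; beyond the scatter). In this assay compound 4 is estimated at 6000 nM, with an expected range of 800 nM to 30000 nM.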

Compound 4, half-maximal inhibitory concentration: 1400 nM
Estimate against measurement, compound 4: 4.3-fold (0.63 log units) above; low and high end bracket the measured number.
By their numbers in this assay, from the lowest: compounds 4 and 3 (each within the scatter of the next); then compound 2; then compound 1.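

In this assay, among these compounds, 4-methoxyphenyl in place of pentyl on the aromatic nitrogen gives a 46-fold lower number from compound 1 to compound 4 (1.66 log units; beyond the scatter), the only step read at this position, so a change at this nitrogen alone moves the number by a large amount. Compound 4 and compound 3 stand within the scatter of each other, while compound 2 lies apart from both, so having a ring-bearing group here does not by itself fix the number. Nothing measured explains the step. Going by these compounds, whether plain phenyl would match 4-methoxyphenyl remains open, as does what a benzyl group, a chloro group on the phenyl ring or a longer chain would do.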